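Adding a Carboxy Group to Compound 3

The compounds below may be only part of what the source reports. "The series", "measured", "known", "first", "only" and "open" are said of these compounds alone.

Measured so far, in an assay on cells for activation of Cystic fibrosis transmembrane conductance regulator (Homo sapiens), read by fluorescence, with stated times of 10 min and 12 s; a higher number here means that more compound is needed for the effect, a lower number that less compound is needed:
Compound 1, `CCN(CC)c1nc(Nc2ccc([N+](=O)[O-])cc2)nc(OC(C(F)(F)F)C(F)(F)F)n1`, gives 18000 nM.
Compound 2, `CCN(CC)c1nc(Nc2ccc3ncsc3c2)nc(OC(C(F)(F)F)C(F)(F)F)n1`, gives 50 nM.
Compound 3, `CCN(CC)c1nc(Nc2ccccc2)nc(OCC(F)(F)C(F)F)n1`, gives 2000 nM.

Compound 3 stands second highest of the three numbers: compound 1 sits above it and compound 2 well below it. Compound 4, `CCN(CC)c1nc(Nc2ccc(C(=O)O)cc2)nc(OCC(F)(F)C(F)F)n1`, keeps the shared core and the ether chain of compound 3 and differs from it in one place: carboxy in place of hydrogen on an aromatic carbon.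

Among the compounds with values here, only one step between compounds that differ in a single place is known, a 360-fold lower number from compound 1 to compound 2 (2.56 log units; beyond the scatter), and it exchanges the whole aryl group on the nitrogen rather than adding a group to it, so it bears on the present change only loosely. It does show that what hangs on that nitrogen can move this assay a long way. Compound 1 carries a nitro group at the same place on the ring where compound 4 carries its carboxy group, and compound 1 gives a higher number than compound 3, though those two also differ in their ether chains. On this slim basis a moderate rise in the number is expected for compound 4, a 3.0-fold higher number from compound 3 to compound 4 (0.48 log units; beyond the scatter). The estimate for compound 4 is 6000 nM, with a range from 1500 nM to 25000 nM.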

Compound 4, half-maximal effective concentration: 2500 nM
Estimate against measurement, compound 4: 2.4-fold (0.38 log units) above; the measured number falls inside the stated range.
By their numbers in this assay, from the lowest: compound 2; then compounds 3 and 4 (each within the scatter of the next); then compound 1.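

In this assay, carboxy in place of hydrogen on the aromatic carbon para to a large group gives a 1.3-fold higher number from compound 3 to compound 4 (0.10 log units; within the scatter), so compound 3 and compound 4 cannot be told apart here. The earlier step showed only that exchanging the whole aryl group on the nitrogen can shift the number a long way, whereas this one shows that the phenyl ring of compound 3 can carry a carboxy group, with its 3 heavy atoms, at this place without a shift beyond the scatter. Nothing measured here explains this result.

On these data alone, whether this holds for carboxy alone or for other groups at the same place, such as an amine, a methyl ester or a primary amide, stays open. As far as these compounds go, compound 1 and compound 4 differ in both the group on the ring and the ether chain, so the effect of a nitro group against a carboxy group on the ether chain of compound 3 also remains unknown.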